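Branched alkyl groups on the imine nitrogen of the cyanoguanidine series

This account rests on a few compounds, and the source may have more. Where it says the series, first, only, none or still open, it means among the compounds named here.

Measured so far in a functional assay on the whole organism (blood, strain Wistar-Okamoto) with Rattus norvegicus as the target, with a stated time of 5 days; on this read-out higher numbers stand for an effect only at larger amounts of compound and lower numbers for an effect already at smaller amounts:
- compound 1 `CCC(CC)/N=C(\NC#N)Nc1ccncc1`: 2.5 mg/kg
- compound 2 `N#CN/C(=N\C1CCCCC1)Nc1ccncc1`: 20 mg/kg
- compound 3 `CC(C)(C)/N=C(\NC#N)Nc1ccncc1`: 2.5 mg/kg

Compound 3 sits level with compound 1; together they give the lowest numbers of the three in this assay. Compound 2 is the only one set apart: an 8.0-fold lower number from compound 2 to compound 3 (0.90 log units; beyond the scatter), while no change at the digits printed from compound 1 to compound 3 (within the scatter). For the measured compounds named here, the one step beyond the scatter is thus the one that trades a ring for an open branched group; between the two open branched groups nothing moves.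

Compound 4 `CCC(C)(CC)/N=C(\NC#N)Nc1ccncc1` is not yet measured. Its change from compound 3 is 1-ethyl-1-methylpropyl in place of tert-butyl on a double-bonded nitrogen. Both steps into compound 3 bear on it. The move from pentan-3-yl to tert-butyl, an open branched group to another, gave no change beyond the scatter in this assay; only the cyclohexyl of compound 2 stood out. The group entering in compound 4 is again an open branched group with no ring, so no step beyond the scatter is expected: no change at the digits printed from compound 3 to compound 4 (within the scatter). For compound 4 the estimate in this assay is 2.5 mg/kg, with a range from 1.2 mg/kg to 6 mg/kg.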

Compound 4, minimum effective dose: 0.5 mg/kg
For compound 4 the middle estimate is 5.0-fold (0.70 log units) above the measured one, and the stated range ends above it.
By their numbers in this assay, from the lowest: compound 4; then compounds 1 and 3 (each within the scatter of the next); then compound 2.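

In this assay, the open branched groups on a double-bonded nitrogen turn out not to be interchangeable: 1-ethyl-1-methylpropyl in place of tert-butyl gives a 5.0-fold lower number from compound 3 to compound 4 (0.70 log units; beyond the scatter), although pentan-3-yl and tert-butyl had stood level. The same group also separates from pentan-3-yl, where methyl in place of hydrogen on a saturated chain carbon bound to a double-bonded nitrogen and two saturated chain carbons gives a 5.0-fold lower number from compound 1 to compound 4 (0.70 log units; beyond the scatter), and its distance from the cyclohexyl group is the widest in the series, with a 40-fold lower number from compound 2 to compound 4 (1.60 log units; beyond the scatter). Nothing available on these compounds accounts for the steps at this position.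

The compounds shown leave open whether a longer chain on the same saturated carbon, such as 1,1-diethylpropyl, would carry the numbers in this assay lower still or reverse the step. They also leave open how this position would respond to 1-methylcyclohexyl, which joins a ring to the fully substituted carbon, or to an ether oxygen or an amine placed in the branched chain.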